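Compound 3 to compound 4: bromo for ethynyl

The source may hold more compounds than are shown below. What is called first, only, known or untested is meant among the compounds shown, and "the series" means these compounds.

Measured in a functional assay on SK-OV-3 cells (Homo sapiens) for cytotoxicity, read by resazurin assay (on this read-out lower numbers stand for stronger inhibition and higher numbers for weaker inhibition), and given per compound:
- compound 1 `C#Cc1cccc(Nc2ncnc3cc(NC(=O)c4ccc(C(=O)Nc5ccccc5N)cc4)ccc23)c1` gives the assay limit > 50000 nM and no number
- compound 2 `C#Cc1cccc(Nc2ncnc3ccc(NC(=O)c4ccc(C(=O)Nc5ccccc5N)s4)cc23)c1` gives the assay limit > 50000 nM and no number
- compound 3 `C#Cc1cccc(Nc2ncnc3ccc(OCc4ccc(C(=O)Nc5ccccc5N)cc4)cc23)c1` gives 5100 nM as a number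

Within the data shown here, compound 3 holds the only number in the set, as the other two compounds give limits only. Compound 4 `Nc1ccccc1NC(=O)c1ccc(COc2ccc3ncnc(Nc4cccc(Br)c4)c3c2)cc1` has bromo in place of ethynyl on an aromatic carbon and otherwise matches compound 3. Among the measured compounds shown here, no measured pair shows this change, so no direction is favoured. The estimated change a 1.2-fold higher number from compound 3 to compound 4 (0.07 log units; within the scatter) is expected to stay within the usual scatter. For compound 4 the expected value is 6000 nM (estimated range 1800 nM to 20000 nM).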

Compound 4, half-maximal inhibitory concentration: 6300 nM
Compound 4: the middle estimate sits 1.1-fold (0.02 log units) below what was measured; the range from low to high includes it.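

In this assay, this position on the 3-ethynylphenyl group gives its first readable step, a 1.2-fold higher number from compound 3 to compound 4 (0.09 log units; within the scatter). With bromo in place of ethynyl on this aromatic carbon, the read-out stays within the scatter, so the two groups cannot be told apart here. Compounds 1 and 2 could not show this, as both carry ethynyl and neither gives a number, only a limit: the limit of > 50000 nM in this assay, at which 2 of the 4 values shown sit.

Still open, from the compounds shown here alone, is whether an amine, a carboxylic acid or a methoxy group at this position would also stay within the scatter. Going by these compounds, whether bromo behaves the same way on the cores of compounds 1 and 2 also remains open.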